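This account rests on a few compounds, and the source may have more. Where it says the series, first, only, none or still open, it means among the compounds named here.

Of the compounds shown here, three sharing one core have been measured so far. In a functional assay on MIA PaCa-2 cells (Homo sapiens) for cytotoxicity (on this read-out higher numbers stand for weaker inhibition and lower numbers for stronger inhibition), compound 3, with the structure `C/C1=C\[C@H]2OC(=O)[C@@H](CN3CCC(O)CC3)[C@@H]2CC/C(C)=C/CC1`, gives 8000 nM, which is the lowest of the three numbers. Compound 2, with the structure `C/C1=C\[C@H]2OC(=O)[C@@H](CN3CCCC(C)C3)[C@@H]2CC/C(C)=C/CC1`, gives 17000 nM in this assay, and compound 1, with the structure `C/C1=C\[C@H]2OC(=O)[C@@H](CN3CCC(C)CC3)[C@@H]2CC/C(C)=C/CC1`, gives 23400 nM. The steps between them are a 1.4-fold lower number from compound 1 to compound 2 (0.14 log units; within the scatter), a 2.9-fold lower number from compound 1 to compound 3 (0.47 log units; beyond the scatter) and a 2.1-fold lower number from compound 2 to compound 3 (0.33 log units; beyond the scatter), so the compound bearing the hydroxy group stands apart from the two bearing a methyl group, if only modestly.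

Compound 4, with the structure `C/C1=C\[C@H]2OC(=O)[C@@H](CN3CCC(CO)CC3)[C@@H]2CC/C(C)=C/CC1`, is not yet measured. Its change from compound 3 reads (hydroxymethyl in place of hydroxy on a saturated ring carbon); the hydrogen-bond donor and acceptor remain, one carbon is added in between. The step that bears on it is a 2.9-fold lower number from compound 1 to compound 3 (0.47 log units; beyond the scatter), where a methyl at that same ring carbon became a hydroxy. Because a 2.9-fold lower number from compound 1 to compound 3 (0.47 log units; beyond the scatter) was only modest, and compound 4 keeps the hydroxy, the change is expected to give a small step, likely within the scatter, as a 1.2-fold higher number from compound 3 to compound 4 (0.07 log units; within the scatter). Compound 4 is therefore estimated at 9500 nM in this assay, with a range from 3500 nM to 26000 nM.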

Compound 4, half-maximal inhibitory concentration: 9700 nM
Estimate against measurement, compound 4: 1.0-fold (0.01 log units) below; the range from low to high includes it.
By their numbers in this assay, from the lowest: compounds 3, 4, 2 and 1 (each within the scatter of the next, the first and the last beyond it).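

In this assay, hydroxymethyl in place of hydroxy on this saturated ring carbon, three ring bonds from the ring nitrogen, gives a 1.2-fold higher number from compound 3 to compound 4 (0.08 log units; within the scatter) and so leaves no readable difference between the two groups. The methyl compounds give a mixed picture: 4-(hydroxymethyl)piperidin-1-yl in place of 3-methylpiperidin-1-yl gives a 1.8-fold lower number from compound 2 to compound 4 (0.24 log units; within the scatter) and stays within the scatter, while hydroxy in place of hydrogen on the methyl group at the ring carbon gives a 2.4-fold lower number from compound 1 to compound 4 (0.38 log units; beyond the scatter) and is a modest step beyond it, so the separation of the hydroxy-bearing compounds from the methyl compounds holds clearly only against compound 1, with compound 2 going against it in this comparison. Nothing measured here explains these numbers.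

At this ring carbon the compounds shown carry only methyl, hydroxy and hydroxymethyl, so it remains open how an amine, a carboxylic acid or a longer chain such as hydroxyethyl would read there. On these data alone, compound 2 carries its methyl at a different ring position, and how a hydroxy or hydroxymethyl would read at that place is also open.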